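A few compounds are considered here, and "the series" means these few. Any claim that something is new, unique, unknown or untested is made for them only; others in the source may bear on it.

Measured so far in a functional assay on a cell-free system (plasma, Homo sapiens), with a stated time of 3 min; a higher number here means a weaker inhibitor, a lower number a stronger inhibitor
- compound 1 `CC(C)(C)[C@@H](O)C(=O)N1C[C@@H]2C[C@@H]2[C@H]1C(=O)NCc1cc(Cl)ccc1-n1cnnn1` gives 570 nM
- compound 2 `CC(C)(C)C[C@@H](O)C(=O)N1C[C@@H]2C[C@@H]2[C@H]1C(=O)NCc1cc(Cl)ccc1-n1cnnn1` gives 910 nM
- compound 3 `O=C(NCc1cc(Cl)ccc1-n1cnnn1)[C@@H]1[C@H]2C[C@H]2CN1C(=O)[C@H](O)Cc1ccccc1` gives 1200 nM

Compound 3 lies within the scatter of its nearest neighbour, as a 1.3-fold higher number from compound 2 to compound 3 (0.12 log units; within the scatter) shows, and only modestly apart from the furthest, as a 2.1-fold higher number from compound 1 to compound 3 (0.32 log units; beyond the scatter) shows.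

Compound 4 `O=C(NCc1cc(Cl)ccc1-n1cnnn1)[C@@H]1[C@H]2C[C@H]2CN1C(=O)[C@H](O)Cn1cccn1` carries 1H-pyrazol-1-yl in place of phenyl, on the same saturated chain carbon: 1H-pyrazol-1-yl in place of phenyl on a saturated chain carbon, two bonds along the chain from a carbonyl carbon and an oxygen on a saturated carbon.

Earlier changes at this place moved the number little, as in a 1.6-fold higher number from compound 1 to compound 2 (0.20 log units; within the scatter). None of them swapped a carbon-only ring for one with hetero atoms, so the data give only a weak guide. No clear step beyond the scatter is therefore expected, and the estimated change is a 1.3-fold higher number from compound 3 to compound 4 (0.10 log units; within the scatter).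

For compound 4 the expected value is 1500 nM, with an estimated range from 500 nM to 4500 nM.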

Compound 4, half-maximal inhibitory concentration: 1800 nM
The estimate for compound 4 lay 1.2-fold (0.08 log units) below the measured number; the range from low to high includes it.
By their numbers in this assay, from the lowest: compounds 1, 2, 3 and 4 (each within the scatter of the next, the first and the last beyond it).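

In this assay, swapping a carbon-only ring for one with hetero atoms, 1H-pyrazol-1-yl in place of phenyl, stays within the scatter (a 1.5-fold higher number from compound 3 to compound 4 (0.18 log units; within the scatter)), so this position tolerates that change here. The same holds for 1H-pyrazol-1-yl in place of tert-butyl (a 2.0-fold higher number from compound 2 to compound 4 (0.30 log units; within the scatter)), while (1H-pyrazol-1-yl)methyl in place of tert-butyl gives a modest step beyond it (a 3.2-fold higher number from compound 1 to compound 4 (0.50 log units; beyond the scatter)). No measurement shown accounts for these steps.

Still open, from the compounds shown here alone, is whether an amine, a carboxylic acid or a pyridine ring at this position would shift the number further.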